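A few compounds are considered here, and "the series" means these few. Any claim that something is new, unique, unknown or untested is made for them only; others in the source may bear on it.

In a functional assay (muscle tissue) with Cavia porcellus as the target (a higher number here means that more compound is needed for the effect, a lower number that less compound is needed), compound 1 (`COC(=O)C1=C(C)N=C(C)/C(=C(\O)OC)C1c1ccc(F)cc1`), which carries 4-fluorophenyl, gives 129 nM as its half-maximal effective concentration. Compound 2 (`COC(=O)C1=C(C)N=C(C)/C(=C(\O)OC)C1c1ccccc1F`), with 2-fluorophenyl, gives 42.7 nM on the same read-out, and compound 3 (`COC(=O)C1=C(C)N=C(C)/C(=C(\O)OC)C1c1ccc(Br)cc1`), with 4-bromophenyl, gives 540 nM there, the highest number of the three. Compound 4 (`C=Cc1ccccc1C1C(C(=O)OC)=C(C)N=C(C)/C1=C(\O)OC`) has not yet been measured. It differs from compound 3 in one place: 2-vinylphenyl stands in place of 4-bromophenyl on a saturated ring carbon (2-vinylphenyl in place of 4-bromophenyl on a saturated ring carbon). Among the compounds with values here, three measured steps bear on this change. Putting bromo in place of fluoro gave a 4.2-fold higher number from compound 1 to compound 3 (0.62 log units; beyond the scatter) and so offers a modest hint that losing the bromo may lower the number. Putting 2-fluorophenyl in place of 4-fluorophenyl gave a 3.0-fold lower number from compound 1 to compound 2 (0.48 log units; beyond the scatter) as a modest step. The large step of a 13-fold higher number from compound 2 to compound 3 (1.10 log units; beyond the scatter) matters most, since compound 2 is the closest measured match: 2-fluorophenyl and 2-vinylphenyl carry the same position number. Within the data shown here, no compound with a vinyl group has been measured, so this reading rests on a single fluoro example. A large step to a lower number is therefore expected, and the estimated change is a 6.0-fold lower number from compound 3 to compound 4 (0.78 log units; beyond the scatter) in this assay for now. For compound 4 the expected value is 90 nM with an estimated range from 20 nM to 400 nM in all.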

Compound 4, half-maximal effective concentration: 4.47 nM
Beside the measured number, compound 4's estimate is 20-fold (1.30 log units) above it; measured number below the stated range.
By their numbers in this assay, from the lowest: compound 4; then compound 2; then compound 1; then compound 3.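

In this assay, replacing 2-fluorophenyl with 2-vinylphenyl gave a 9.6-fold lower number from compound 2 to compound 4 (0.98 log units; beyond the scatter) and so showed that the group on the aromatic ring, not only its place there, strongly shapes the read-out. Measured against the two 4-substituted compounds, the change reaches a 29-fold lower number from compound 1 to compound 4 (1.46 log units; beyond the scatter) and a 120-fold lower number from compound 3 to compound 4 (2.08 log units; beyond the scatter), which widens the span seen at this saturated ring carbon well beyond what the three earlier compounds had shown and leaves compound 4 with the lowest number of the four, its steps to all the others lying beyond the scatter. Nothing available explains why 2-vinylphenyl gives so much lower a number than the other three aryl groups.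

Whether the low number depends on the double bond stays open, since the compounds shown do not tell how an ethyl or ethynyl group would compare with vinyl in 2-vinylphenyl. They also leave open whether 4-vinylphenyl would match 2-vinylphenyl and whether 2-bromophenyl would fall nearer to 2-fluorophenyl or to 2-vinylphenyl, as bromo appears here only in 4-bromophenyl.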